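Amine substituent on the shared core: aryl versus alkyl

The compounds below may be only part of what the source reports. "The series", "measured", "known", "first", "only" and "open" are said of these compounds alone.

Compound 3 `O=C1C(NC2CC2)=CC(=O)c2c1nc1n2[C@H]2OC[C@@H](O)[C@H]2OC1` reaches only a limit in a functional assay on MCF7 cells (Homo sapiens) for inhibition, read by sulforhodamine B assay; a lower number here means a stronger inhibitor, a higher number a weaker inhibitor; in this assay compound 3 gives > 16000 nM. Compound 2 `O=C1C(N2CCCC2)=CC(=O)c2c1nc1n2[C@H]2OC[C@@H](O)[C@H]2OC1` likewise sits at a limit, and in this assay compound 2 gives > 16000 nM. Within the data shown here, compound 1 `Cc1ccc(NC2=CC(=O)c3c(nc4n3[C@H]3OC[C@@H](O)[C@H]3OC4)C2=O)cc1C` carries a (3,4-dimethylphenyl)amino group and is the one compound with a number: in this assay compound 1 gives 4950 nM. The step of an at least 3.2-fold higher number from compound 1 to compound 3 (0.50 log units; beyond the scatter) and the step of an at least 3.2-fold higher number from compound 1 to compound 2 (0.50 log units; beyond the scatter) both run from the aryl amine to an alkyl amine and both cross the scatter, though the limit of > 16000 nM in this assay, at which 2 of the 3 values shown sit, leaves their full size unreadable. The step that the two limits leave unreadable from compound 2 to compound 3 cannot be read at all.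

Compound 4 `O=C1C(Nc2cccc(F)c2)=CC(=O)c2c1nc1n2[C@H]2OC[C@@H](O)[C@H]2OC1` differs from compound 3 by 3-fluorophenyl in place of cyclopropyl on an amine nitrogen. This returns the amine to an aryl substituent, the direction opposite to the step from compound 1 to compound 3, so the expected step of an at least 2.6-fold lower number from compound 3 to compound 4 (0.42 log units; beyond the scatter) is a lower number, of at least the size that the reverse step set. Compound 4 is therefore expected to give about 6000 nM, within 2500 nM to 16000 nM.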

Compound 4, half-maximal inhibitory concentration: > 4000 nM
Compound 4: no number, only a limit (the forecaster's own chance of this, stated with the estimate: 20%); the middle value lies beyond the limit too.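

In this assay compound 4 gives > 4000 nM, which is a limit and not a number. Among these compounds, no step linking compound 1, compound 2 or compound 3 to compound 4 can be read. Going by these compounds, whether (3-fluorophenyl)amino on the shared core matches the (3,4-dimethylphenyl)amino group of compound 1 remains open.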